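From Ethylamino to Isopropylamino on a Shared Core

The compounds below may be only part of what the source reports. "The series", "measured", "known", "first", "only" and "open" are said of these compounds alone.

Among the compounds with values here, compound 2 `CCNC(=O)N1C[C@@H](O[C@H](C)c2cc(C(F)(F)F)cc(C(F)(F)F)c2)[C@H](c2ccc(F)cc2)C1` is one of two compounds measured in an assay on CHO cells for displacement of a labelled ligand from Substance-P receptor (Homo sapiens); on this read-out lower numbers stand for stronger inhibition and higher numbers for weaker inhibition; compound 2 gives 0.1 nM, the higher of the two numbers, while compound 1 `CC(=O)N1CCC(C(=O)N2C[C@@H](O[C@H](C)c3cc(C(F)(F)F)cc(C(F)(F)F)c3)[C@H](c3ccc(F)cc3)C2)CC1` gives 0.07 nM. Within the data shown here, the only measured step, a 1.4-fold higher number from compound 1 to compound 2 (0.15 log units; within the scatter), replaces 1-acetylpiperidin-4-yl by ethylamino on the carbonyl carbon and stays within the scatter. Compound 3 `CC(C)NC(=O)N1C[C@@H](O[C@H](C)c2cc(C(F)(F)F)cc(C(F)(F)F)c2)[C@H](c2ccc(F)cc2)C1` differs from compound 2 by methyl in place of hydrogen on a saturated chain carbon bound to an amide-type nitrogen and a saturated chain carbon, so that ethylcarbamoyl becomes isopropylcarbamoyl. Among the measured compounds shown here, no measured step touches this carbon. For the measured compounds named here, the one step that bears on the region at all, a 1.4-fold higher number from compound 1 to compound 2 (0.15 log units; within the scatter), shows that an exchange on the carbonyl carbon moved the number little; the step to compound 3 is therefore expected to be no larger than the scatter, a 1.2-fold higher number from compound 2 to compound 3 (0.08 log units; within the scatter). For compound 3 the estimate in this assay is 0.12 nM, expected to fall between 0.05 nM and 0.3 nM.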

Compound 3, half-maximal inhibitory concentration: 0.06 nM
Compound 3: middle estimate off by 2.0-fold (0.30 log units), on the high side, and the stated range covers the measured number.
By their numbers in this assay, from the lowest: compounds 3, 1 and 2 (each within the scatter of the next).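

In this assay, methyl in place of hydrogen on the saturated chain carbon bound to an amide-type nitrogen and a saturated chain carbon gives a 1.7-fold lower number from compound 2 to compound 3 (0.22 log units; within the scatter). Within the data shown here, this is the first reading at this carbon, and turning ethylcarbamoyl into isopropylcarbamoyl leaves the number within the scatter. The exchange on the carbonyl carbon, a 1.2-fold lower number from compound 1 to compound 3 (0.07 log units; within the scatter), also stays within the scatter, so isopropylamino can no more be told apart from 1-acetylpiperidin-4-yl on this read-out than ethylamino could, and nothing given here accounts for these results.

From the compounds shown here alone, whether a tert-butyl group or a longer chain in place of isopropyl would keep the number at this level remains open. So does the outcome of putting a hydroxyl group or a carboxylic acid on the same chain carbon.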